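The source may report more compounds than this note shows. Statements on the series, on what has been measured and on what is new or still open speak of the compounds shown alone.

Among the measured compounds shown here, compound 2 `COc1cccc(OC)c1OCCNCCOc1ccccc1OCc1ccc([N+](=O)[O-])cc1` sits highest of the two numbers in an assay on CHO cells for displacement of a labelled ligand from Alpha-1A adrenergic receptor (Homo sapiens) (a lower number here means a stronger inhibitor, a higher number a weaker inhibitor), at 1.26 nM; compound 1 `COc1cccc(OC)c1OCCNCCOc1ccccc1OCc1cccc([N+](=O)[O-])c1` gives 0.316 nM, and the only measured step is a 4.0-fold higher number from compound 1 to compound 2 (0.60 log units; beyond the scatter). Compound 3 `COc1ccccc1COc1ccccc1OCCNCCOc1c(OC)cccc1OC` carries 2-methoxyphenyl in place of 4-nitrophenyl on a saturated chain carbon bound to an oxygen on an aromatic ring. For the measured compounds named here, the step from compound 1 to compound 2 changed only where the nitro group stands on its ring; no measured step exchanges a nitro group for a methoxy group, so the single step bears on this change only loosely. A step in either direction is therefore expected, with no firm lean, a 1.3-fold lower number from compound 2 to compound 3 (0.10 log units; within the scatter). For compound 3 the estimate is 1 nM, within 0.25 nM to 4 nM.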

Compound 3, inhibition constant: 2 nM
Estimate against measurement, compound 3: 2.0-fold (0.30 log units) below; the range from low to high includes it.
By their numbers in this assay, from the lowest: compound 1; then compounds 2 and 3 (each within the scatter of the next).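

In this assay, 2-methoxyphenyl on a saturated chain carbon bound to an oxygen on an aromatic ring stands level with 4-nitrophenyl (a 1.6-fold higher number from compound 2 to compound 3 (0.20 log units; within the scatter)), so a nitro group is not needed for a low nanomolar number here. Against 3-nitrophenyl, the same group gives a step beyond the scatter (a 6.3-fold higher number from compound 1 to compound 3 (0.80 log units; beyond the scatter)), which leaves compound 1 apart from compound 2 and compound 3. No measurement on hand accounts for these steps. Still open, from the compounds shown here alone, is how an unsubstituted phenyl would read at this position, and whether an amine or a carboxylic acid on the ring would hold the number.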